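A few compounds are considered here, and "the series" means these few. Any claim that something is new, unique, unknown or untested is made for them only; others in the source may bear on it.

Compound 1 `CCCc1nc(C)c2c(C)nn(C)c(=O)n12` gives > 48000 nM in a functional assay for inhibition, with Homo sapiens as the target (a higher number here means a weaker inhibitor, a lower number a stronger inhibitor), which is a limit of the assay rather than a number.
Compound 2 `CCCc1nc(C)c2c(C)nn(CC(=O)O)c(=O)n12` gives > 48000 nM in this assay, again only a limit of the assay.

Compound 2 therefore stands only at a limit: its half-maximal inhibitory concentration lies beyond what this assay reports, and nothing more precise about it is known. For the measured compounds named here, the one measured step, a step that the two limits leave unreadable from compound 1 to compound 2, cannot be read in size, since both of its ends sit at the same limit; this is the point made by the limit of > 48000 nM in this assay, at which 2 of the 2 values shown sit. Compound 3 `CCCc1nc(C)c2c(C)nn(CC(O)CO)c(=O)n12` carries the change (1,2-dihydroxyethyl in place of carboxy on a saturated chain carbon bound to an aromatic nitrogen). Going by the values given here, no measured step bears on this change in a readable way: the only step runs from one limit to another and shows neither gain nor loss. The expectation for compound 3 is accordingly a step of a number no higher from compound 2 to compound 3 (the limit leaves the size open) in this assay, that is, none beyond the scatter, with compound 3 most likely reported once more only as a limit. Compound 3 is estimated at 48000 nM, with a range from 10000 nM to 200000 nM.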

Compound 3, half-maximal inhibitory concentration: > 48000 nM
Compound 3 gave a limit, no number; the forecaster's own chance of this, stated with the estimate: 85%; the middle value lies on the limit itself.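

In this assay, for the compounds shown here, compound 3 ends at a limit of the assay, as compound 1 and compound 2 do, so no step among the three can be read in size: the limit of > 48000 nM in this assay, at which 3 of the 3 values shown sit. The compounds shown leave open how strong each of them really is, and whether replacing carboxymethyl with 2,3-dihydroxypropyl changes inhibition at all.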